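This account rests on a few compounds, and the source may have more. Where it says the series, first, only, none or still open, it means among the compounds named here.

Measured compounds:
compound 1 `O=C(CSc1nnc(N2CCN(c3cc4c(cc3F)c(=O)c(C(=O)O)cn4C3CC3)CC2)s1)c1ccc(Cl)cc1` 3 ug/mL
compound 2 `O=C(CSc1nnc(N2CCN(c3cc4c(cc3F)c(=O)c(C(=O)O)cn4C3CC3)CC2)s1)c1ccc(Br)cc1` 6 ug/mL

In an ADME assay on Vero cells (Chlorocebus sabaeus) for inhibition, read by MTT assay, with a stated time of 96 h (a higher number here means a weaker inhibitor, a lower number a stronger inhibitor), compound 1 gives 3 ug/mL, the lowest of the two numbers; its nearest neighbour is compound 2, which gives 6 ug/mL. Among the measured compounds shown here, the only step within the set, a 2.0-fold higher number from compound 1 to compound 2 (0.30 log units; within the scatter), stays inside the scatter, so the two compounds cannot be ordered.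

Compound 3 `CCn1cc(C(=O)O)c(=O)c2cc(F)c(N3CCN(c4nnc(SCC(=O)c5ccc(Cl)cc5)s4)CC3)cc21` differs from compound 1 by ethyl in place of cyclopropyl on an aromatic nitrogen. For the measured compounds named here, no measured pair changes this position: the one step on record, a 2.0-fold higher number from compound 1 to compound 2 (0.30 log units; within the scatter), concerns the halogen on the distal aromatic ring and tells nothing about the group on the aromatic nitrogen of the shared core. Going by the values given here, with no precedent, the default expectation is a step no larger than the scatter, in either direction, so compound 3 is expected near compound 1, as a 1.2-fold higher number from compound 1 to compound 3 (0.07 log units; within the scatter). The estimate for compound 3 in this assay is 3.5 ug/mL, with a range from 1.2 ug/mL to 10 ug/mL that is kept wide for want of a direct comparison.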

Compound 3, half-maximal inhibitory concentration: 4 ug/mL
Beside the measured number, compound 3's estimate is 1.1-fold (0.06 log units) below it; measured number inside the range.
By their numbers in this assay, from the lowest: compounds 1, 3 and 2 (each within the scatter of the next).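

In this assay the group on the aromatic nitrogen now has its first measured step, a 1.3-fold higher number from compound 1 to compound 3 (0.12 log units; within the scatter), which lies within the scatter. With the chloro ring and the rest of the shared core held constant, ethyl in place of cyclopropyl removes the three-membered ring and one carbon without a step beyond the scatter, so this pair gives no sign that the ring is needed at this position. Nothing on hand explains this result.

Still open, from the compounds shown here alone, is whether a longer chain such as butyl, or a phenyl ring, on the aromatic nitrogen would stay within the scatter of compound 1. Also open, going by these compounds, is whether ethyl in place of cyclopropyl would give a comparable step with the bromo ring of compound 2 .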